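From methyl to a longer benzyl chain on sulfur

The source may hold more compounds than are shown below. What is called first, only, known or untested is meant among the compounds shown, and "the series" means these compounds.

For the measured compounds named here, in a functional assay on HeLa cells (Homo sapiens) for antiproliferative activity, read by resazurin assay (a lower number here means a stronger inhibitor, a higher number a weaker inhibitor), compound 2 (`CSC(=S)SCC(=O)c1ccc(C)cc1`) gives 3160 nM as the lower of the only two numbers measured so far. Compound 1 (`Cc1ccc(C(=O)CSC(=S)SC(C)C)cc1`) stands higher at 25100 nM in this assay with isopropyl in the place where compound 2 has methyl.

The next structure is compound 3 (`Cc1ccc(C(=O)CSC(=S)SCCc2ccccc2)cc1`), which departs from compound 2 by one change. That change is benzyl in place of hydrogen on a saturated chain carbon bound to a sulfur and it puts benzyl in place of hydrogen on a saturated chain carbon bound to a sulfur.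

Going by the values given here, only one measured step bears on this, namely a 7.9-fold lower number from compound 1 to compound 2 (0.90 log units; beyond the scatter) when methyl replaced isopropyl on a sulfur. It is modest but beyond the scatter. Read in reverse, it suggests a higher number once methyl is built upon, so compound 3 is expected to sit above compound 2, as compound 1 does at 25100 nM with isopropyl. Among the compounds with values here, no measured compound carries benzyl, so this evidence is thin.

The expected change is a 2.5-fold higher number from compound 2 to compound 3 (0.40 log units; beyond the scatter) as a step of similar or smaller size. For compound 3 the estimate is 8000 nM with an expected range from 2000 nM to 30000 nM in this assay overall.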

Compound 3, half-maximal inhibitory concentration: 39800 nM
Compound 3: the middle estimate sits 5.0-fold (0.70 log units) below what was measured; the whole stated range lies below it.
By their numbers in this assay, from the lowest: compound 2; then compounds 1 and 3 (each within the scatter of the next).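

In this assay, benzyl in place of hydrogen on a saturated chain carbon bound to a sulfur gives a 13-fold higher number from compound 2 to compound 3 (1.10 log units; beyond the scatter), a large step that shows this position does not accept the addition without a clear loss, and it leaves compound 2, with its methyl, with the lowest number of the three, beyond the scatter from both others. The isopropyl of compound 1, at 25100 nM, and the chain carrying benzyl in compound 3, at 39800 nM, stand within the scatter of each other, so two quite different groups on this sulfur cannot be put in any order, and only methyl stands apart from them. Nothing in the data shown accounts for the size of this step.

Going by these compounds, with only these three groups on the sulfur, it stays open whether the number climbs steadily from methyl or reaches a plateau soon after it. An ethyl group, or an amine or a carboxylic acid at the end of a longer chain, could fall nearer compound 2 or nearer compound 1, and the compounds shown do not settle which.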